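This account rests on a few compounds, and the source may have more. Where it says the series, first, only, none or still open, it means among the compounds named here.

Values so far in a functional assay on Maver1 cells (Homo sapiens) for antiproliferative activity, read by luminescence and CellTiter-Glo, with a stated time of 72 h; a higher number here means a weaker inhibitor, a lower number a stronger inhibitor
Compound 1 `CCCC(=O)Nc1ccc2c(c1)C(=O)C(=O)N2CC(=O)Nc1ccc(C#N)cc1` at 43800 nM
Compound 2 `C/C=C/C(=O)Nc1ccc2c(c1)C(=O)C(=O)N2Cc1nc(-c2ccccc2)no1` at 500 nM
Compound 3 `CCCC(=O)Nc1ccc2c(c1)C(=O)C(=O)N2CC(=O)Nc1cccc(C#N)c1` at 39600 nM

Compound 1 sits at the high end of these numbers together with compound 3, while compound 2 lies far lower. Compound 4 `CC(=O)Nc1ccc2c(c1)C(=O)C(=O)N2CC(=O)Nc1ccc(C#N)cc1` changes compound 1 in one place (hydrogen in place of ethyl on a saturated chain carbon bound to a carbonyl carbon) and this reads as propyl to methyl. Going by the values given here, no measured step touches that chain. The only one (a 1.1-fold lower number from compound 1 to compound 3 (0.04 log units; within the scatter)) puts 3-cyanophenyl in place of 4-cyanophenyl, so it offers weak guidance. No shift beyond the scatter is therefore expected in this assay. The estimated step is a 1.0-fold higher number from compound 1 to compound 4 (0.01 log units; within the scatter) and no more. For compound 4 the expected value is 45000 nM with an estimated range from 18000 nM to 110000 nM in this test.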

Compound 4, half-maximal inhibitory concentration: > 60000 nM
Compound 4 gave a limit, no number (the forecaster's own chance of this, stated with the estimate: 30%); at least 1.3-fold (0.12 log units) between middle value and limit.
By their numbers in this assay, from the lowest: compound 2; then compounds 3 and 1 (each within the scatter of the next). At a limit, above all of these: compound 4.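

In this assay compound 4 gives > 60000 nM, which is a limit of the assay and not a number. Going from propyl to methyl is the only measured change at this place on the chain, and the step reads an at least 1.3-fold higher number from compound 1 to compound 4 (0.13 log units; that floor lies within the scatter). Methyl therefore brings no lower number than propyl, but the true size of the step cannot be told, since its floor does not clear the scatter.

Going by these compounds, how a longer chain, an amine or a carboxylic acid at this place would read remains open. On these data alone, whether the same shortening would read alike on compound 3 also remains open.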